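A few compounds are considered here, and "the series" means these few. Any claim that something is new, unique, unknown or untested is made for them only; others in the source may bear on it.

Four compounds share one core, a ring system carrying four bromine atoms with a short chain on one of its nitrogens. Compound 1 `OC(CCn1nc2c(Br)c(Br)c(Br)c(Br)c2n1)c1ccc(F)cc1` and compound 3 `OC(CCn1nc2c(Br)c(Br)c(Br)c(Br)c2n1)c1ccc(Cl)cc1` carry an aromatic ring at the end of that chain, while compound 2 `C[C@H](O)CCn1nc2c(Br)c(Br)c(Br)c(Br)c2n1` ends in a methyl group. Among the measured compounds shown here, in a functional assay on MCF7 cells (Homo sapiens) for antiproliferative activity, read by MTT assay, with a stated time of 24 h, tested at 100 uM (on this read-out higher numbers stand for a weaker effect at the one concentration tested and lower numbers for a stronger effect), compound 1 gives 0% and compound 3 gives 0%; the one measured step, no change at the digits printed from compound 1 to compound 3 (within the scatter), leaves the read-out unchanged. Compound 2 gives 31%, the highest of the three numbers and beyond the scatter from both others, so on this read-out its effect is the weakest.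

Compound 4 `OCC(O)Cn1nc2c(Br)c(Br)c(Br)c(Br)c2n1` has not yet been measured. It differs from compound 2 in one place: 1,2-dihydroxyethyl in place of 2-hydroxypropyl on a saturated chain carbon bound to an aromatic nitrogen. No measured step changes the chain in this way, so nothing shown speaks directly to the size of this step. For the measured compounds named here, compound 2 at 31% against compound 1 at 0% shows only that the group at the end of the chain can move the number by a large amount. For compound 4 a step of a number 11 percentage points lower from compound 2 to compound 4 (beyond the scatter) is expected, with wide uncertainty. Compound 4 is therefore estimated at 20%, within a range from 0% to 45%.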

Compound 4, a percentage reported as activity, at one concentration (the size of the read-out at that concentration, not a potency): 53%
The estimate for compound 4 lay 33 percentage points below the measured number; measured number above the stated range.
By their numbers in this assay, from the lowest: compounds 1 and 3 (each within the scatter of the next); then compound 2; then compound 4.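

In this assay, putting 1,2-dihydroxyethyl in place of 2-hydroxypropyl gives a number 22 percentage points higher from compound 2 to compound 4 (beyond the scatter), so the effect at the one concentration tested becomes weaker. Among the compounds shown here, the only step measured before this one, a chloro in place of a fluoro on the aromatic ring, left the number unchanged, whereas this change at the saturated chain carbon bound to an aromatic nitrogen moves it beyond the scatter, even though both groups have 4 heavy atoms and neither has a ring. The result therefore shows that this position can respond to a small edit, but nothing measured here gives a reason for the shift.

This single step changes several things at once, going from 1 to 2 hydrogen-bond donors and losing the defined stereocentre, so the compounds shown cannot separate the contribution of each. Going by these compounds, it also remains open whether an amine, a carboxylic acid or a longer chain bearing a hydroxyl at this position would move the number further in the same direction, leave it in place or reverse it.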